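Shortening the Amide Substituent: Cell Tolerance Notes

The source may report more compounds than this note shows. Statements on the series, on what has been measured and on what is new or still open speak of the compounds shown alone.

Compound 2 `COc1ccc(-c2cnc(NC(=O)C3CCOCC3)n2C)cc1` is the starting point here, and in a toxicity assay on THP-1 cells (Homo sapiens) for inhibition (a higher number here means that more compound is tolerated, a lower number that less compound is tolerated), compound 2 gives > 100000 nM, which is a limit of the assay and not a number. Compound 1 `COc1ccc(-c2cnc(NC(=O)CCc3ccccc3)n2C)cc1` also reaches only a limit; compound 1 gives > 100000 nM. Compound 3 `Cc1ccccc1C(=O)Nc1ncc(-c2ccccc2)n1C` likewise stops at a limit, compound 3 giving > 100000 nM. Across the measured set, (the limit of > 100000 nM in this assay, at which 3 of the 3 values shown sit), so the single step within it, a step that the two limits leave unreadable from compound 1 to compound 2, cannot be sized. Compound 4 `CCC(=O)Nc1ncc(-c2ccc(OC)cc2)n1C` differs from compound 2 by ethyl in place of oxan-4-yl on a carbonyl carbon. Among the compounds with values here, no measured step carries a readable size, so nothing points to a shift beyond the scatter in this assay; the expectation is that compound 4 also remains at the limit. Compound 4 is therefore estimated at 150000 nM, in the range 50000 nM to 500000 nM. The expected step, a step that the limit leaves unreadable from compound 2 to compound 4, is taken to be flat.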

Compound 4, half-maximal cytotoxic concentration: > 100000 nM
Compound 4 ended at the assay's limit (the forecaster's own chance of this, stated with the estimate: 85%); the middle value lies beyond the limit too.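

The steps from compound 1 and from compound 2 to compound 4 cannot be read, as each value is a limit and not a number: the limit of > 100000 nM in this assay, at which 4 of the 4 values shown sit. On these data alone, whether any amide substituent shifts tolerance in this assay stays open.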